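Solubility series: replacing the hydroxypiperidine amide with a methyl ester

This account rests on a few compounds, and the source may have more. Where it says the series, first, only, none or still open, it means among the compounds named here.

Compound 2 `Nc1ncc(-c2ccc(C(=O)N3CCC(O)CC3)cc2)nc1-c1ccc(C(F)(F)F)cc1` carries a (4-hydroxypiperidin-1-yl)carbonyl group on one aryl ring. Among the compounds with values here, in a physicochemical assay for solubility, read by HPLC, using the shake flask method, with a stated time of 2 h, at pH 2 (a higher number here means a more soluble compound, a lower number a less soluble compound), compound 2 gives 119000 nM, the only actual number measured. Compound 1 `Nc1ncc(-c2ccc(C(=O)O)cc2)nc1-c1ccc(C(F)(F)F)cc1` bears the free carboxylic acid in the same place. In this assay compound 1 returns only a limit, < 5000 nM, as recorded in the limit of < 5000 nM in this assay, at which 1 of the 2 values shown sits. Within the data shown here, the single measured step, an at least 23-fold higher number from compound 1 to compound 2 (1.37 log units; beyond the scatter), is therefore the whole of the evidence on what this position does to solubility.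

Compound 3 `COC(=O)c1ccc(-c2cnc(N)c(-c3ccc(C(F)(F)F)cc3)n2)cc1` is not yet measured. Relative to compound 2 the change is methoxy in place of 4-hydroxypiperidin-1-yl on a carbonyl carbon. Among the measured compounds shown here, no measured step covers a methoxy at this position. For the measured compounds named here, the only comparison available is an at least 23-fold higher number from compound 1 to compound 2 (1.37 log units; beyond the scatter), in which removing the 4-hydroxypiperidin-1-yl group went with a large move in the opposite direction, and the step from compound 2 to compound 3 can only be read against it. A large downward step is expected, a 24-fold lower number from compound 2 to compound 3 (1.38 log units; beyond the scatter), with a real chance that only a limit is returned. Compound 3 is estimated at 5000 nM, in the range 1000 nM to 25000 nM.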

Compound 3, solubility: < 5000 nM
Compound 3 ended at the assay's limit; the forecaster's own chance of this, stated with the estimate: 55%; the middle value sits exactly at the limit.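

In this assay, methoxy in place of 4-hydroxypiperidin-1-yl on a carbonyl carbon gives an at least 23-fold lower number from compound 2 to compound 3 (1.37 log units; beyond the scatter), so the large step seen earlier with hydroxy in that place is no longer tied to hydroxy alone. The step between compound 1 and compound 3 cannot be read, as both values are limits and not numbers. Compound 2 remains the only compound with an actual number, and the other two end at the same limit: the limit of < 5000 nM in this assay, at which 2 of the 3 values shown sit.

Still open, on these data alone, is which part of the 4-hydroxypiperidin-1-yl group goes with the higher number, the ring, the hydroxyl or the amide nitrogen; a plain piperidin-1-yl amide without the hydroxyl, or an open-chain dimethylamino amide, would separate these. Also open, as far as these compounds go, is how far the true values of compound 1 and compound 3 lie from the limit, so neither the full size of the step nor any ranking of the acid against the methyl ester can be taken from these data.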